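Swapping chloro for trifluoromethyl on a fluoro-bearing ring

The source may report more compounds than this note shows. Statements on the series, on what has been measured and on what is new or still open speak of the compounds shown alone.

Three compounds sharing one core have been measured in an assay on isolated protein for inhibition of Indoleamine 2,3-dioxygenase 1 (Homo sapiens), read by spectrophotometry; on this read-out lower numbers stand for stronger inhibition and higher numbers for weaker inhibition:

compound 1 `O/N=C(/Nc1cccc(Cl)c1)c1ccc2occc2c1` gives 690 nM
compound 2 `O/N=C(/Nc1cccc(C(F)(F)F)c1)c1ccc2occc2c1` gives 1200 nM
compound 3 `O/N=C(/Nc1ccc(F)c(Cl)c1)c1ccc2occc2c1` gives 5200 nM

Compound 3 has the highest number of the three, that is the weakest inhibition; its nearest neighbour is compound 2, and compound 1 lies furthest from it, both gaps being beyond the scatter. The step of a 7.5-fold higher number from compound 1 to compound 3 (0.88 log units; beyond the scatter) came from a fluoro entering in place of hydrogen.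

Compound 4 `O/N=C(/Nc1ccc(F)c(C(F)(F)F)c1)c1ccc2occc2c1` differs from compound 3 in one place: trifluoromethyl in place of chloro on an aromatic carbon. The same exchange has been seen once before, between compound 1 and compound 2, where a 1.7-fold higher number from compound 1 to compound 2 (0.24 log units; within the scatter) stayed within the scatter. Among the compounds with values here, that single precedent is the only guide, and it points to a step of about the same small size here, if any, in the direction of a slightly higher number.

Compound 4 is therefore expected to give 7500 nM in this assay, in a range of 3000 nM to 19000 nM, which means an estimated step of a 1.4-fold higher number from compound 3 to compound 4 (0.16 log units; within the scatter), not beyond the scatter.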

Compound 4, half-maximal inhibitory concentration: 1200 nM
The estimate for compound 4 lay 6.3-fold (0.80 log units) above the measured number, and the stated range ends above it.
By their numbers in this assay, from the lowest: compounds 1, 2 and 4 (each within the scatter of the next); then compound 3.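

The exchange of chloro for trifluoromethyl has no fixed size at this position, as the presence of the fluoro group reverses its direction, giving a 4.3-fold lower number from compound 3 to compound 4 (0.64 log units; beyond the scatter) in this assay, and the two steps clearly disagree: the same change on two cores in this assay, a 1.7-fold higher number (0.24 log units; within the scatter) from compound 1 to compound 2 and a 4.3-fold lower number (0.64 log units; beyond the scatter) from compound 3 to compound 4, 7.5-fold (0.88 log units) apart, beyond the scatter of two such steps. The fluoro group does not carry a fixed penalty either, since alongside trifluoromethyl it gives no change at the digits printed from compound 2 to compound 4 (within the scatter), unlike its clear step alongside chloro: the same change on two cores in this assay, a 7.5-fold higher number (0.88 log units; beyond the scatter) from compound 1 to compound 3 and no change at the digits printed (within the scatter) from compound 2 to compound 4, 7.5-fold (0.88 log units) apart, beyond the scatter of two such steps. The two changes therefore do not simply add up, and among these compounds only the pairing of chloro with fluoro, in compound 3, stands apart from the rest.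

From the compounds shown here alone, it remains open whether a bromo or a methoxy group at this position on the fluoro-bearing ring would follow chloro or trifluoromethyl. These four compounds cannot tell why the two groups depend on each other.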